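Phenylsulfanyl in place of ethyl: cytotoxicity expectation

The compounds below may be only part of what the source reports. "The series", "measured", "known", "first", "only" and "open" are said of these compounds alone.

Compound 1, `CCc1ccc(CN[C@H]2CC(C(=O)O)=C[C@@H](OC(CC)CC)[C@@H]2NC(C)=O)cc1`, gives in an ADME assay on cells (Fibroblast, Gallus gallus) for cytotoxicity, read by CCK-8 assay, with a stated time of 48 h (on this read-out higher numbers stand for lower toxicity in this test and lower numbers for higher toxicity in this test), only a limit of the assay, > 200000 nM.
Compound 2, `CCC(CC)O[C@@H]1C=C(C(=O)O)C[C@H](NCc2ccc(SC(C)CC)cc2)[C@H]1NC(C)=O`, gives in this assay only a limit, > 200000 nM.
Compound 3, `CCC(CC)O[C@@H]1C=C(C(=O)O)C[C@H](NCc2ccc(SC3CCCC3)cc2)[C@H]1NC(C)=O`, gives in this assay only a limit, > 200000 nM.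

Compound 1 stands nowhere definite on these numbers: its value is a limit, and the two other values are limits as well, so nothing ranks it against compound 2 or compound 3. The steps measured are accordingly unreadable: a step that the two limits leave unreadable from compound 1 to compound 2, a step that the two limits leave unreadable from compound 1 to compound 3 and a step that the two limits leave unreadable from compound 2 to compound 3 are each hidden by the two limits. Among the compounds with values here, the one piece of evidence is the limit of > 200000 nM in this assay, at which 3 of the 3 values shown sit.

Compound 4, `CCC(CC)O[C@@H]1C=C(C(=O)O)C[C@H](NCc2ccc(Sc3ccccc3)cc2)[C@H]1NC(C)=O`, differs from compound 1 by phenylsulfanyl in place of ethyl on an aromatic carbon. The steps from compound 1 to compound 2 and from compound 1 to compound 3 also exchange the ethyl for a sulfur-linked group on the same aromatic carbon, and neither gave a readable size. Within the data shown here, no step is therefore expected beyond the scatter; compound 4 is expected to sit again at the limit, so that a step that the limit leaves unreadable from compound 1 to compound 4 is expected to be unreadable. The estimate for compound 4 is 300000 nM, in the range 120000 nM to 800000 nM.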

Compound 4, half-maximal cytotoxic concentration: > 200000 nM
Compound 4: no number, only a limit; the forecaster's own chance of this, stated with the estimate: 85%; the middle value is on the limit's open side.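

In this assay compound 4 gives > 200000 nM, which is a limit of the assay. Its steps from compound 1, compound 2 and compound 3 therefore cannot be read. The compounds shown leave open what value any of them has and whether the groups exchanged on the aromatic carbon differ at all in this assay.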